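Dichlorophenyl Urea in Place of a Trifluoromethylphenyl Urea

The source may report more compounds than this note shows. Statements on the series, on what has been measured and on what is new or still open speak of the compounds shown alone.

compound 1 `O=C(Nc1cccc(-n2cc(-c3ccncc3)c(-c3ccc(Cl)c(O)c3)n2)c1)Nc1cccc(C(F)(F)F)c1`: > 32500 nM
compound 2 `COc1cc(-c2nn(-c3cccc(NC(=O)Nc4cc(C(F)(F)F)cc(C(F)(F)F)c4)c3)cc2-c2ccncc2)ccc1Cl`: > 50000 nM

In a functional assay on SF-268 cells (Homo sapiens) for inhibition, read by sulforhodamine B assay, with a stated time of 48 h (a higher number here means that more compound is tolerated, a lower number that less compound is tolerated), compound 1 gives no number, only the limit of the assay, > 32500 nM (the limit of > 32500 nM in this assay, at which 1 of the 2 values shown sits). Compound 2 likewise gives only a limit, > 50000 nM (the limit of > 50000 nM in this assay, at which 1 of the 2 values shown sits). Compound 1 therefore stands at a limit with no measured value to place it. Compound 3 `O=C(Nc1cccc(-n2cc(-c3ccncc3)c(-c3ccc(Cl)c(O)c3)n2)c1)Nc1ccc(Cl)c(Cl)c1` differs from compound 1 by 3,4-dichlorophenyl in place of 3-(trifluoromethyl)phenyl on an amide-type nitrogen. For the measured compounds named here, no step between measured compounds exists, so nothing beyond the scatter is expected: the expected step is a number no higher from compound 1 to compound 3 (the limit leaves the size open). Compound 3 is thus expected to give 32500 nM, between 15000 nM and 80000 nM, most likely again as a limit.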

Compound 3, concentration lethal to 50% of the cells: > 32500 nM
Compound 3: a limit, no number (the forecaster's own chance of this, stated with the estimate: 80%); the middle value lies on the limit itself.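

For the compounds shown here, compound 3 gives only a limit in this assay, > 32500 nM, as compound 1 does, so no step between compound 1 and compound 3 can be read. The compounds shown leave open whether 3,4-dichlorophenyl in place of 3-(trifluoromethyl)phenyl changes this read-out at all.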